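Replacing Octyl with Phenyl on the Aromatic Ring

The source may hold more compounds than are shown below. What is called first, only, known or untested is meant among the compounds shown, and "the series" means these compounds.

- compound 1 `CC(=O)N[C@@H](CO)[C@H](O)/C=C/c1ccc(-c2ccccc2)cc1`: no result reported
- compound 2 `CCCCCCCCCCCCC/C=C/C(=O)[C@H](CO)NC(C)=O`: 175000 nM
- compound 3 `CCCCCCCCc1ccc(/C=C/C(=O)[C@H](CO)NC(C)=O)cc1`: 65000 nM

In a functional assay on HepG2 cells (Homo sapiens) for antiproliferative activity, read by resazurin assay, with a stated time of 24 h (on this read-out lower numbers stand for stronger inhibition and higher numbers for weaker inhibition), compound 3 gives 65000 nM, the lowest of the two numbers available, and the nearest other number is that of compound 2 at 175000 nM. Compound 4 `CC(=O)N[C@@H](CO)C(=O)/C=C/c1ccc(-c2ccccc2)cc1` has not been measured yet. It differs from compound 3 in one group: phenyl in place of octyl on an aromatic carbon. Among the measured compounds shown here, no measured pair shows this kind of change, so the expectation is tentative. In this assay the expected change is no larger than the scatter, leaning slightly toward weaker inhibition. The estimated step is a 1.4-fold higher number from compound 3 to compound 4 (0.14 log units; within the scatter). For compound 4 the expected value is 90000 nM, within an estimated range of 30000 nM to 220000 nM.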

Compound 4, half-maximal inhibitory concentration: 41000 nM
Estimate against measurement, compound 4: 2.2-fold (0.34 log units) above; low and high end bracket the measured number.
By their numbers in this assay, from the lowest: compounds 4 and 3 (each within the scatter of the next); then compound 2.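

In this assay, putting phenyl in place of octyl on the aromatic carbon para to a large group gives a 1.6-fold lower number from compound 3 to compound 4 (0.20 log units; within the scatter). Among the compounds shown here, this is the first view of this position with a ring rather than a chain, and the two compounds cannot be told apart, so a flexible octyl chain is not needed here to keep this level of activity. Nothing available explains why the two compounds read alike.

Still open, on these data alone, is whether an amine or a carboxylic acid at this place would move the number beyond the scatter. The same goes for a chain longer than octyl.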